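Working notes on the step from compound 3 to compound 4

The compounds below may be only part of what the source reports. "The series", "measured", "known", "first", "only" and "open" are said of these compounds alone.

The series shares the core of compound 1 `COc1cccc(CNc2ncnc3c2ncn3C2CCCCO2)c1`, which in an ADME assay on MCF7 cells (Homo sapiens) for cytotoxicity, with a stated time of 72 h (a lower number here means a stronger inhibitor, a higher number a weaker inhibitor), gives 97000 nM. Compound 2 `COc1ccc(CNc2ncnc3c2ncn3C2CCCCO2)cc1` reaches only the limit of the assay, > 100000 nM. Compound 3 `COc1cc(CNc2ncnc3c2ncn3C2CCCCO2)ccc1O` likewise sits at a limit, > 100000 nM. Compound 3 therefore stands at the floor of what the assay reports, with no number of its own. The step from compound 3 to compound 4 `COc1ccc(CNc2ncnc3c2ncn3C2CCCCO2)cc1OC` is methyl in place of hydrogen on an oxygen on an aromatic ring. Going by the values given here, no measured step covers exactly this change. Among the compounds with values here, the two measured steps, an at least 1.0-fold higher number from compound 1 to compound 2 (0.01 log units; that floor lies within the scatter) and an at least 1.0-fold higher number from compound 1 to compound 3 (0.01 log units; that floor lies within the scatter), both run to the limit and lie within the scatter, so they show only that changes around the methoxyphenyl have not moved the readout off that limit (the limit of > 100000 nM in this assay, at which 2 of the 3 values shown sit). In this assay no step beyond the scatter is expected, a step that the limit leaves unreadable from compound 3 to compound 4. Compound 4 is expected to give 150000 nM, between 70000 nM and 400000 nM, most likely reported again only as a limit.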

Compound 4, half-maximal inhibitory concentration: > 100000 nM
Compound 4: only a limit was reported; the forecaster's own chance of this, stated with the estimate: 80%; the middle value lies beyond the limit too.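

Converting the hydroxy of compound 3 to methoxy brings no number into this assay: compound 4 gives > 100000 nM as a limit of the assay and not as a measured value. Of the steps to compound 4, the one that can be read is an at least 1.0-fold higher number from compound 1 to compound 4 (0.01 log units; that floor lies within the scatter) and the others, with limits at both ends, cannot be read. The oxygen on the aromatic ring therefore now carries hydrogen in compound 3 and methyl in compound 4 with no separation visible in the readout, and the series gathers further at one ceiling: the limit of > 100000 nM in this assay, at which 3 of the 4 values shown sit.

On these data alone, how far compound 2, compound 3 and compound 4 lie beyond the limit stays open, so any true differences among them remain hidden. Also open, as far as these compounds go, is whether an amine or a carboxylic acid on the aromatic ring, or a longer chain on that oxygen, would give a readable number in this assay at all.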